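A few compounds are considered here, and "the series" means these few. Any claim that something is new, unique, unknown or untested is made for them only; others in the source may bear on it.

In a functional assay on DU-145 cells (Homo sapiens) for inhibition, read by MTT assay, with a stated time of 48 h (on this read-out lower numbers stand for stronger inhibition and higher numbers for weaker inhibition), compound 3 `CC(C)n1c(/C=C2\SC(=O)N(CC(=O)N3CCCCC3)C2=O)nc2ccccc21` gives 42200 nM, within the scatter of compound 1 `Cn1c(/C=C2\SC(=O)N(CC(=O)Nc3cc(C(C)(C)C)on3)C2=O)nc2ccccc21` at 31400 nM. Compound 2 `CC(C)n1c(/C=C2\SC(=O)N(CC(=O)N3CCCC3)C2=O)nc2ccccc21` is reported only as a limit, > 50000 nM. Compound 4 `CC(C)n1c(/C=C2\SC(=O)N(CC(=O)Nc3cc(C(C)(C)C)on3)C2=O)nc2ccccc21` departs from compound 3 by (5-(tert-butyl)-1,2-oxazol-3-yl)amino in place of piperidin-1-yl on a carbonyl carbon, with (5-(tert-butyl)-1,2-oxazol-3-yl)amino in place of piperidin-1-yl on a carbonyl carbon. For the measured compounds named here, the only measured step at this place is an at least 1.1-fold lower number from compound 2 to compound 3 (0.07 log units; that floor lies within the scatter), so it gives little guidance. The entering group also occurs in compound 1, which reads 31400 nM. On these values, no step beyond the scatter is expected in this assay, and the expected step is a 1.4-fold lower number from compound 3 to compound 4 (0.15 log units; within the scatter). For compound 4 the estimated value is 30000 nM, with an expected range of 13000 nM to 50000 nM.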

Compound 4, half-maximal inhibitory concentration: > 50000 nM
Compound 4: no number, only a limit; the forecaster's own chance of this, stated with the estimate: 20%; middle value at least 1.6-fold (0.22 log units) from the limit.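

In this assay the (5-(tert-butyl)-1,2-oxazol-3-yl)amino group in place of piperidin-1-yl on a carbonyl carbon gives an at least 1.1-fold higher number from compound 3 to compound 4 (0.07 log units; that floor lies within the scatter) and isopropyl in place of methyl on an aromatic nitrogen gives an at least 1.5-fold higher number from compound 1 to compound 4 (0.20 log units; that floor lies within the scatter) with both floors within the scatter, so neither change is yet shown to matter. The step from compound 2 to compound 4 cannot be read. True step sizes stay hidden because the read-out ends at a limit: the limit of > 50000 nM in this assay, at which 2 of the 4 values shown sit.

Open, as far as these compounds go, is whether ethyl on the aromatic nitrogen, or morpholin-4-yl on the carbonyl carbon, would give a number clear of that limit.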